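The source may hold more compounds than are shown below. What is called first, only, known or untested is meant among the compounds shown, and "the series" means these compounds.

Working notes on the series. The shared core of compound 1 `NC(=O)Cn1c(-c2ccc(C(F)(F)F)cc2)nc2cccnc21` carries a trifluoromethyl-substituted phenyl and an unsubstituted amide on the saturated chain carbon; compound 2 `CN(C)C(=O)Cn1c(-c2cccc(Cl)c2)nc2cccnc21` carries a chloro-substituted phenyl with a dimethylamide; compound 3 `CCN(CC)C(=O)Cn1c(-c2ccc(Cl)cc2)nc2cccnc21` carries a chloro-substituted phenyl with a diethylamide. In a functional assay on the whole organism with Mus musculus as the target (on this read-out lower numbers stand for an effect already at smaller amounts and higher numbers for an effect only at larger amounts of compound), compound 1 gives 11.7 mg/kg. In this assay compound 3 gives 16 mg/kg, which stands alongside compound 1 within the usual scatter, so no order between the two can be read. For compound 2 only a limit of this assay is known, > 56.2 mg/kg; < 100 mg/kg (2 entries), and the same picture returns in the several entries of compound 2 in this assay, > 56.2 mg/kg; < 100 mg/kg (2 entries).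

Compound 4 `CN(C)CCN(C)C(=O)Cn1c(-c2ccc(Cl)cc2)nc2cccnc21` keeps the chloro-substituted phenyl and the carbonyl on the saturated chain carbon and differs from compound 3 by one change: (2-(dimethylamino)ethyl)(methyl)amino in place of diethylamino on a carbonyl carbon. Going by the values given here, no measured step between two compounds is available to gauge it, and the run from the unsubstituted amide through the dimethylamide to the diethylamide gives no single direction. The expectation is a step from compound 3 to compound 4 of a 1.6-fold higher number from compound 3 to compound 4 (0.19 log units; within the scatter), most likely within the scatter, with a modest chance of a higher number. Compound 4 is accordingly estimated at 25 mg/kg in this assay, with a range from 8 mg/kg to 80 mg/kg.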

Compound 4, dose for half-maximal effect: 100 mg/kg
For compound 4 the middle estimate is 4.0-fold (0.60 log units) below the measured one; the measured number lies above the stated range.
By their numbers in this assay, from the lowest: compounds 1 and 3 (each within the scatter of the next); then compound 4.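

In this assay the amine part on the carbonyl carbon is not a neutral place in the series: (2-(dimethylamino)ethyl)(methyl)amino in place of diethylamino gives a 6.3-fold higher number from compound 3 to compound 4 (0.80 log units; beyond the scatter). Going by these compounds alone, this is the first change at a single place that can be read here, and it lies beyond the scatter, whereas the earlier compounds differ from one another in more than one place and gave no size for any change at this position. The change takes the amine part from 5 to 7 heavy atoms and from 0 to 1 hydrogen-bond acceptors, but nothing shown ties the step to either count or to any other feature of the group, and no information shown bears on its cause.

From the compounds shown here alone, it stays open whether the step comes from the terminal dimethylamino group, the two-carbon chain or the methyl on the amide nitrogen, which a pyrrolidine amide, a morpholine amide or a longer chain ending in an amine could separate. Going by these compounds, it also stays open whether the same step would appear with the trifluoromethyl-substituted phenyl of compound 1.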